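A larger ring group on the amine nitrogen

The compounds below may be only part of what the source reports. "The series", "measured", "known", "first", "only" and "open" are said of these compounds alone.

Measured in a functional assay on CWR22R cells (Homo sapiens) for antiproliferative activity, read by CCK-8 assay, with a stated time of 6 days; a lower number here means a stronger inhibitor, a higher number a weaker inhibitor:
- Compound 1 `C[C@@H](Cn1ccc(-c2ccc(C#N)c(Cl)c2)n1)NC(=O)c1ccccc1F`: "not determined" (no result reported)
- Compound 2 `C[C@@H](Cn1ccc(-c2ccc(C#N)c(Cl)c2)n1)Nc1ncccn1`: 12500 nM

Going by the values given here, compound 2 carries the only number in this small set, so it cannot be ranked against another measured compound, and compound 1 offers no comparison. Compound 3 `C[C@@H](Cn1ccc(-c2ccc(C#N)c(Cl)c2)n1)Nc1ncnc2nc[nH]c12` keeps the shared core and changes only the group on the amine nitrogen: a group of 9 heavy atoms (5 carbon, 4 nitrogen; one five-membered aromatic ring with 2 hetero atoms, one six-membered aromatic ring with 2 hetero atoms) in place of a group of 6 heavy atoms (4 carbon, 2 nitrogen; one six-membered aromatic ring with 2 hetero atoms), on an amine nitrogen. The pyrimidin-2-yl group leaves, and a group with one five-membered and one six-membered aromatic ring enters.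

Among the compounds with values here, no pair of measured compounds shows what a change at this place does, so any expectation here is tentative. A modest gain in this assay seems more likely than a loss, meaning a lower number than the 12500 nM of compound 2, though the result may not clearly exceed the usual scatter. The estimate corresponds to an expected 2.1-fold lower number from compound 2 to compound 3 (0.32 log units; beyond the scatter). Compound 3 is estimated at 6000 nM, with an expected range from 1500 nM to 25000 nM.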

Compound 3, half-maximal inhibitory concentration: 4240 nM
The estimate for compound 3 lay 1.4-fold (0.15 log units) above the measured number; the range from low to high includes it.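

In this assay, going by these compounds alone, the change on the amine nitrogen gives a 2.9-fold lower number from compound 2 to compound 3 (0.47 log units; beyond the scatter), the first measured step at this position. It shows that the place accepts a larger group with one five-membered and one six-membered aromatic ring in place of the pyrimidin-2-yl group, without a loss and with a modest gain that lies beyond the scatter; compound 1, with no result reported, could not show this. No evidence bears on what in the entering group lies behind this gain.

The compounds shown leave open whether the second ring, the hydrogen-bond donor, or the added nitrogen atoms matter most, as all of these change together in this single step. Going by these compounds, a lone imidazole ring on the amine nitrogen, or a pyrimidin-2-yl ring carrying an amine or a carboxylic acid, would help to separate these features, and how the amide of compound 1 compares with either ring group in this assay also remains unknown.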